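This account rests on a few compounds, and the source may have more. Where it says the series, first, only, none or still open, it means among the compounds named here.

Compound 2 `COc1ncc(-c2ccccc2)cc1[C@@H](c1ccccc1)[C@@](O)(CCN(C)C)c1cccc(F)c1F` carries the shared core with a 2,3-difluorophenyl group on the carbinol carbon. In a toxicity assay on Vero cells (Chlorocebus sabaeus) for cytotoxicity (on this read-out higher numbers stand for lower toxicity in this test and lower numbers for higher toxicity in this test), compound 2 gives > 50 ug/mL, which is a limit of the assay and not a number. Compound 1 `COc1ncc(-c2ccccc2)cc1[C@@H](c1ccccc1)[C@@](O)(CCN(C)C)c1cc(F)ccc1F` differs from it only in carrying 2,5-difluorophenyl at the same place. In this assay compound 1 gives > 50 ug/mL, again a limit of the assay. The step that the two limits leave unreadable from compound 1 to compound 2 cannot be sized, as both values sit at the limit of > 50 ug/mL in this assay, at which 2 of the 2 values shown sit. Compound 3 `COc1ncc(-c2ccccc2)cc1[C@@H](c1ccccc1)[C@@](O)(CCN(C)C)c1cccc2ccccc12` is not yet measured in this assay. It differs from compound 2 by naphthalen-1-yl in place of 2,3-difluorophenyl on a saturated chain carbon bound to an oxygen on a saturated carbon and two saturated chain carbons. Among the measured compounds shown here, the only measured step, from compound 1 to compound 2, concerns a different exchange at the same place and is unreadable, so no size for the new step can be taken from it. Both measured compounds stand at the limit, so compound 3 is expected to stay near it, with the step of a number no higher from compound 2 to compound 3 (the limit leaves the size open) expected to be small or again unreadable. The estimate for compound 3 in this assay is 50 ug/mL, with a range from 20 ug/mL to 100 ug/mL.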

Compound 3, half-maximal cytotoxic concentration: > 50 ug/mL
Compound 3: only a limit was reported (the forecaster's own chance of this, stated with the estimate: 60%); the middle value lies on the limit itself.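

In this assay compound 3 gives > 50 ug/mL, a limit of the assay and not a number. The steps among compound 1, compound 2 and compound 3 cannot be read, as all three values sit at the same limit: the limit of > 50 ug/mL in this assay, at which 3 of the 3 values shown sit.

The compounds shown leave open whether 2,5-difluorophenyl, 2,3-difluorophenyl and naphthalen-1-yl differ in this assay at concentrations past this limit.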